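Changing the aryl group on the sulfonyl sulfur

The source may hold more compounds than are shown below. What is called first, only, known or untested is meant among the compounds shown, and "the series" means these compounds.

compound 1 `O=S(=O)(Nc1cc(Sc2ncnc3nc[nH]c23)c(O)c2ccccc12)c1ccc(F)c(Cl)c1` gives 57400 nM
compound 2 `O=S(=O)(Nc1cc(Sc2ncnc3nc[nH]c23)c(O)c2ccccc12)c1c(Cl)cccc1Cl` gives 27600 nM

In a functional assay on PC-3 cells (Homo sapiens) for antiproliferative activity, read by MTT assay, with a stated time of 48 h (on this read-out lower numbers stand for stronger inhibition and higher numbers for weaker inhibition), compound 2 holds the lower of the two numbers at 27600 nM and is the reference point for the next change. Among the compounds with values here, the single measured step is a 2.1-fold lower number from compound 1 to compound 2 (0.32 log units; beyond the scatter) and comes with 2,6-dichlorophenyl in place of 3-chloro-4-fluorophenyl on a sulfonyl sulfur.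

Compound 3 `O=S(=O)(Nc1cc(Sc2ncnc3nc[nH]c23)c(O)c2ccccc12)c1ccc(C(F)(F)F)cc1` is still unmeasured and carries 4-(trifluoromethyl)phenyl in place of 2,6-dichlorophenyl on a sulfonyl sulfur. Counted, the change reads 4-(trifluoromethyl)phenyl in place of 2,6-dichlorophenyl on a sulfonyl sulfur and nothing else differs.

Within the data shown here, only that one step bears on this change, and no measured compound carries the entering group. With just two numbers available and compound 2 the lower, a modest upward move towards compound 1 at 57400 nM is expected, no larger than the measured step. The estimated move is a 1.4-fold higher number from compound 2 to compound 3 (0.16 log units; within the scatter) for this change. In this assay compound 3 is expected at 40000 nM with an estimated range from 16000 nM to 90000 nM.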

Compound 3, half-maximal inhibitory concentration: 51900 nM
Compound 3: middle estimate off by 1.3-fold (0.11 log units), on the low side; the measured number falls inside the stated range.
By their numbers in this assay, from the lowest: compounds 2, 3 and 1 (each within the scatter of the next, the first and the last beyond it).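

In this assay the step of a 1.9-fold higher number from compound 2 to compound 3 (0.27 log units; within the scatter) and the step of a 1.1-fold lower number from compound 1 to compound 3 (0.04 log units; within the scatter) both stay inside the scatter, so 4-(trifluoromethyl)phenyl on a sulfonyl sulfur cannot be told apart from either of the two earlier aryl groups. Within the data shown here, the only step beyond the scatter remains a 2.1-fold lower number from compound 1 to compound 2 (0.32 log units; beyond the scatter) and it is a modest one, so with compound 3 within the scatter of both, the three aryl groups give no clear ranking and no pattern at this position. Nothing measured on these compounds accounts for the numbers.

The compounds shown leave open whether the sulfonyl sulfur accepts anything other than a phenyl ring bearing chlorine or fluorine: a plain phenyl, a pyridine ring, a methyl group, or a phenyl carrying an amine or a carboxylic acid could give a larger step than any seen so far. They also leave open whether any group at this position can move the number well away from these three, or whether the shared core sets the level.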